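The source may report more compounds than this note shows. Statements on the series, on what has been measured and on what is new or still open speak of the compounds shown alone.

Measured in a functional assay on the whole organism (strain NMRI) with Mus musculus as the target, with a stated time of 60 min, at a dose of 10 mg/kg by the intraperitoneal route; on this read-out lower numbers stand for a weaker effect and higher numbers for a stronger effect at the one dose given:
compound 1, `S=c1[nH]nc(Cc2ccc(Cl)cc2Oc2ccccc2Cl)[nH]1`: 139%
compound 2, `CCSc1nnc(Cc2ccccc2Oc2ccccc2)[nH]1`: 142%
compound 3, `CCCSc1nnc(Cc2ccc(Cl)cc2Oc2ccccc2F)[nH]1`: 127%

Compound 1 stands second highest of the three numbers. Compound 2 is within the scatter of compound 1, so the two cannot be told apart; compound 3 sits below compound 1 beyond the scatter. Among the measured compounds shown here, no two measured compounds differ in a single place, so no measured step guides the next change.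

Compound 4, `Nc1nnc(Cc2ccc(Cl)cc2Oc2ccccc2Cl)o1`, is not yet measured in this assay. It differs from compound 1 thus: a group of 6 heavy atoms (2 carbon, 3 nitrogen, 1 oxygen; one five-membered aromatic ring with 3 hetero atoms) in place of a group of 6 heavy atoms (2 carbon, 3 nitrogen, 1 sulfur; one five-membered aromatic ring with 3 hetero atoms), on a saturated chain carbon bound to an aromatic carbon. For the measured compounds named here, for such an exchange no step is known; a modest downward step in this assay, near the edge of the scatter, is expected. Compound 4 is therefore estimated at 125%, with a range from 100% to 150%. The expected step is a number 14 percentage points lower from compound 1 to compound 4 (beyond the scatter).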

Compound 4, a percentage reported as activity, at one dose (the size of the read-out at that dose, not a potency): 132%
Compound 4: middle estimate off by 7 percentage points, on the low side, within the range that was stated.
By their numbers in this assay, from the lowest: compounds 3, 4, 1 and 2 (each within the scatter of the next, the first and the last beyond it).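

Replacing the sulfur-bearing ring of compound 1 with 5-amino-1,3,4-oxadiazol-2-yl, on a saturated chain carbon bound to an aromatic carbon, gives in this assay a change of a number 7 percentage points lower from compound 1 to compound 4 (within the scatter) and so leaves the read-out at this one dose unchanged within the scatter. Among the compounds shown here, this is the first single-place comparison, and it shows that this position accepts this exchange, though it rests on one pair only. No measurement shown here accounts for the result.

Going by these compounds, it remains open whether a carboxylic acid or a simple amine at this place would hold the read-out equally well. On these data alone, it also remains open whether the same exchange would give a similar step with other substituents on the two aromatic rings.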